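The source may report more compounds than this note shows. Statements on the series, on what has been measured and on what is new or still open speak of the compounds shown alone.

The compounds with a result:
compound 1, `COc1cccc(NC(=O)c2cc(Cl)ccc2O)c1`, in an ADME assay for permeability, using PAMPA; a higher number here means that the compound crosses the layer faster, a lower number that the compound crosses the layer more slowly: 43 10^-6 cm/s
compound 2, `COc1ccc(Cl)c(NC(=O)c2cc(Cl)ccc2O)c1`, in this assay: 34 10^-6 cm/s
compound 3, `O=C(Nc1ccc(C(F)(F)F)cc1)c1cc(Br)ccc1O`, in this assay: "not determined" (no result reported)

Compound 4, `O=C(Nc1ccc(C(F)(F)F)c(Cl)c1)c1cc(Br)ccc1O`, has not yet been measured. It arises from compound 3 by chloro in place of hydrogen on an aromatic carbon. The same kind of change, (chloro in place of hydrogen on an aromatic carbon), links compound 1 and compound 2, and there a 1.3-fold lower number from compound 1 to compound 2 (0.10 log units; within the scatter). The two places are not identical: in compound 2 the entering chloro is ortho to a large group and para to a methoxy group, whereas in compound 4 it is ortho to a trifluoromethyl group and meta to a large group. The difference between the two cores is not broken down here.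

Since compound 3 gave no number in this assay, the earlier step cannot simply be added to a starting value. The expectation for compound 4 therefore rests only on the observation that a 1.3-fold lower number from compound 1 to compound 2 (0.10 log units; within the scatter) stayed within the scatter, so a number in the range seen for the measured compounds is expected, with wide uncertainty. Compound 4 is expected to give 30 10^-6 cm/s in this assay, estimated between 10 10^-6 cm/s and 60 10^-6 cm/s.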

Compound 4, apparent permeability: 23.2 10^-6 cm/s
Compound 4: the middle estimate sits 1.3-fold (0.11 log units) above what was measured, and the stated range covers the measured number.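

Compound 3 has no number in this assay, so the change from compound 3 to compound 4, chloro in place of hydrogen, cannot be read as a step. The compounds shown leave open how this chloro shifts the read-out on the core of compound 3. No further data bear on the result for compound 4.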